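The compounds below may be only part of what the source reports. "The series", "measured", "known", "first", "only" and "open" are said of these compounds alone.

The series rests on a shared core carrying an aminomethyl group on a three-membered ring, a tertiary amide and an aromatic substituent. Compound 1 `C=C(F)CN(C)C(=O)[C@@]1(c2ccsc2)C[C@H]1CN`, compound 2 `CCN(CC)C(=O)[C@@]1(c2ccc(Cl)s2)C[C@H]1CN` and compound 3 `NC[C@@H]1C[C@@]1(C(=O)N1CCc2ccccc2C1)c1ccsc1` were all tested in an assay on HEK293 cells for inhibition of sodium-dependent dopamine transporter (Homo sapiens); on this read-out higher numbers stand for weaker inhibition and lower numbers for stronger inhibition. In this assay compound 1 gave only a limit, > 10000 nM. For compound 2 this assay likewise reported only a limit, > 10000 nM. Compound 3 also stayed at a limit in this assay, > 10000 nM. Among the compounds with values here, compound 2 therefore stands nowhere in particular among the three: every value shown is a limit, and the whole picture is summed up by the limit of > 10000 nM in this assay, at which 3 of the 3 values shown sit, so no step between measured compounds can be sized.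

Compound 4 `CCN(CC)C(=O)[C@@]1(c2ccccn2)C[C@H]1CN` keeps the diethylamide of compound 2 and alters the aromatic substituent: pyridin-2-yl in place of 5-chlorothiophen-2-yl on a saturated ring carbon. Within the data shown here, with no measured step anywhere in the set, the expected change from compound 2 to compound 4 is stated cautiously as a step that the limit leaves unreadable from compound 2 to compound 4, that is, no movement that would clear the limit beyond the usual scatter. Compound 4 is accordingly estimated at 15000 nM in this assay, within a range from 5000 nM to 50000 nM, and it is expected that the assay will most likely again report only a limit.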

Compound 4, half-maximal inhibitory concentration: > 10000 nM
Compound 4: only a limit was reported; the forecaster's own chance of this, stated with the estimate: 80%; the middle value lies beyond the limit too.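

In this assay compound 4 also gave only a limit, > 10000 nM. Compound 2 and compound 4 therefore yield no readable step, and the set sits at a single limit: the limit of > 10000 nM in this assay, at which 4 of the 4 values shown sit.

The compounds shown leave open whether pyridin-2-yl in place of 5-chlorothiophen-2-yl changes inhibition at all, and how the four compounds rank against one another.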